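A few compounds are considered here, and "the series" means these few. Any claim that something is new, unique, unknown or untested is made for them only; others in the source may bear on it.

Measured in a functional assay on HepG2 cells (Homo sapiens) for cytotoxicity, read by XTT assay, with a stated time of 6 days (a higher number here means a weaker inhibitor, a lower number a stronger inhibitor), each entry a limit:
Compound 1 `CN(C)c1ncnc2[nH]cc(Sc3cccs3)c12`: > 25000 nM
Compound 2 `Nc1ncnc2[nH]cc(Sc3cccs3)c12`: > 25000 nM
Compound 3 `c1csc(Sc2c[nH]c3ncnc(-c4cccs4)c23)c1`: > 25000 nM

Compound 3 gives only a limit, > 25000 nM, and it shares that position with the other two compounds: the limit of > 25000 nM in this assay, at which 3 of the 3 values shown sit. Compound 4 `c1coc(-c2ncnc3[nH]cc(Sc4cccs4)c23)c1` differs from it by furan-2-yl in place of thiophen-2-yl on an aromatic carbon.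

Three measured exchanges of the group on this aromatic carbon bear on the change. They are a step that the two limits leave unreadable from compound 1 to compound 2, a step that the two limits leave unreadable from compound 1 to compound 3 and a step that the two limits leave unreadable from compound 2 to compound 3. Going by the values given here, none of them gives a size, so the series offers no measured step to carry over. With compound 3 at > 25000 nM, no step beyond the scatter is expected in this assay. The expected change is a step that the limit leaves unreadable from compound 3 to compound 4, and a result reported only as a limit is the likeliest outcome. Compound 4 is estimated at 30000 nM, with an expected range from 15000 nM to 60000 nM.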

Compound 4, half-maximal inhibitory concentration: > 25000 nM
Compound 4: only a limit was reported; the forecaster's own chance of this, stated with the estimate: 85%; the middle value lies beyond the limit too.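

In this assay compound 4 gives only a limit, > 25000 nM. Going by these compounds alone, no step from compound 1, compound 2 or compound 3 to compound 4 can be read: the limit of > 25000 nM in this assay, at which 4 of the 4 values shown sit. The compounds shown leave open whether any exchange of the group on this aromatic carbon changes cytotoxicity.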